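Ethyl on the saturated chain of compound 2

This account rests on a few compounds, and the source may have more. Where it says the series, first, only, none or still open, it means among the compounds named here.

In a functional assay on SW480 cells (Homo sapiens) for antiproliferative activity, read by MTT assay, with a stated time of 48 h (a higher number here means a weaker inhibitor, a lower number a stronger inhibitor), compound 1 `CCCCCCC(CCO)n1cnc2c(Cl)nc(F)nc21` gives 12900 nM and compound 2 `CCCCCCC(CCO)n1cnc2c(Cl)nc(Cl)nc21` gives 12400 nM as the second number of a level pair. Chloro in place of fluoro on an aromatic carbon is a 1.0-fold lower number from compound 1 to compound 2 (0.02 log units; within the scatter) and so leaves the two together at the low end of the numbers shown. Compound 3 `CCCCCCC(CCO)n1cnc2c(N)nc(Cl)nc21` gives > 50000 nM as a limit of the assay and not a number. Amino in place of chloro on an aromatic carbon is an at least 4.0-fold higher number from compound 2 to compound 3 (0.60 log units; beyond the scatter) and is the only step so far beyond the scatter.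

Compound 4 `CCCCCCCCC(CCO)n1cnc2c(Cl)nc(Cl)nc21` differs from compound 2 by ethyl in place of hydrogen on a saturated chain carbon, seven bonds along the chain from an aromatic nitrogen in one place, ethyl in place of hydrogen on a saturated chain carbon, seven bonds along the chain from an aromatic nitrogen. Neither measured step touches this chain, since both fall on an aromatic carbon, so they give no direct size for the change. With compound 2 at 12400 nM as the anchor, no step beyond the scatter is expected in this assay on this evidence. The estimated step is a 1.2-fold lower number from compound 2 to compound 4 (0.09 log units; within the scatter) and the uncertainty on it is wide in both directions. Compound 4 is expected at 10000 nM with an estimated range from 3500 nM to 28000 nM as the working estimate.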

Compound 4, half-maximal inhibitory concentration: 24000 nM
The estimate for compound 4 lay 2.4-fold (0.38 log units) below the measured number, within the range that was stated.
By their numbers in this assay, from the lowest: compounds 2, 1 and 4 (each within the scatter of the next). At a limit, above all of these: compound 3.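

In this assay, going by these compounds alone, ethyl in place of hydrogen on a saturated chain carbon, seven bonds along the chain from an aromatic nitrogen, gives the first reading of a change on the chain rather than on the aromatic part of the shared core: a 1.9-fold higher number from compound 2 to compound 4 (0.29 log units; within the scatter). Within the data shown here, this position therefore accepts two further carbons without a step beyond the scatter, while the only step beyond the scatter remains the one on an aromatic carbon, an at least 4.0-fold higher number from compound 2 to compound 3 (0.60 log units; beyond the scatter). The one available supporting observation concerns the assay limit and has no bearing on the chain change, so it offers no explanation for this result.

A single step on one background cannot show whether a longer chain would stay within the scatter or move beyond it, and a trend with chain length cannot be drawn from it. Also open, on these data alone, is whether an amine or a carboxylic acid at the end of this chain would be tolerated in the same way, or whether the ethyl change would read the same on the amino compound 3.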